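A few compounds are considered here, and "the series" means these few. Any claim that something is new, unique, unknown or untested is made for them only; others in the source may bear on it.

In a functional assay on ONS-76 cells (Homo sapiens) for antiproliferative activity, read by CellTiter-Glo, with a stated time of 72 h (on this read-out higher numbers stand for weaker inhibition and lower numbers for stronger inhibition), compound 1 `COc1cc(NC(=O)NOCCCCCC(=O)NO)c2ncccc2c1` gives 2670 nM, while compound 2 `COc1cc(NC(=O)NOCCCCCC(=O)NO)c2nccc(C)c2c1` gives 590 nM. Compound 2 therefore holds the lower of the two numbers and is the stronger inhibitor of the pair. Compound 3 `COc1cc(NC(=O)NOCCCCCC(=O)NO)c2nc(OC)cc(C)c2c1` keeps the methyl group of compound 2 and adds one further change: methoxy in place of hydrogen on an aromatic carbon. This is methoxy in place of hydrogen on an aromatic carbon, next to the ring nitrogen and meta to a methyl group. For the measured compounds named here, only one measured step bears on it, and that step involved methyl in place of hydrogen on an aromatic carbon, a different group at a different carbon. Going by the values given here, no measurement yet shows what methoxy does here. With only a 4.5-fold lower number from compound 1 to compound 2 (0.66 log units; beyond the scatter) as a guide, a step no larger than that modest one is expected in this assay, probably toward a lower number, and it may well stay within the scatter. The expected change is a 1.4-fold lower number from compound 2 to compound 3 (0.15 log units; within the scatter). For compound 3 the estimated value is 420 nM. The expected range for compound 3 runs from 140 nM to 1250 nM.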

Compound 3, half-maximal inhibitory concentration: 650 nM
For compound 3 the middle estimate is 1.5-fold (0.19 log units) below the measured one; the measured number falls inside the stated range.
By their numbers in this assay, from the lowest: compounds 2 and 3 (each within the scatter of the next); then compound 1.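

In this assay, methoxy in place of hydrogen on an aromatic carbon, next to the ring nitrogen and meta to a methyl group, gives a 1.1-fold higher number from compound 2 to compound 3 (0.04 log units; within the scatter). For the compounds shown here, this is the first measurement at this carbon, and it shows that the position takes a group of 2 heavy atoms, with 1 hydrogen-bond acceptor, without a step beyond the scatter, whereas the methyl group at a different carbon gave a 4.5-fold lower number from compound 1 to compound 2 (0.66 log units; beyond the scatter). Nothing measured alongside these numbers accounts for the result, so the near match between the two compounds stays an observation without an explanation.

Methoxy is the only group seen at this carbon so far, so it remains open whether an amine, a carboxylic acid or a longer chain such as butoxy would also stay within the scatter or would shift the number in either direction. Also open, on these data alone, is whether methoxy at this carbon would give a similarly small step on the core of compound 1, which lacks the methyl group.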